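Sulfonyl aryl swap on the hydroxycyclohexadienone indole series

The source may hold more compounds than are shown below. What is called first, only, known or untested is meant among the compounds shown, and "the series" means these compounds.

Compound 2 `O=C1C=CC(O)(c2cc3ccccc3n2S(=O)(=O)c2ccc3ccccc3c2)C=C1` stands second highest of the three numbers in a functional assay on cells (Panel NCI-60 (60 carcinoma cell lines), Homo sapiens) (on this read-out lower numbers stand for stronger inhibition of growth and higher numbers for weaker inhibition of growth), with 190 nM. Compound 1 `O=C1C=CC(O)(c2cc3ccc(F)cc3n2S(=O)(=O)c2ccccc2)C=C1` gives 16 nM and compound 3 `O=C1C=CC(O)(c2cc3ccccc3[nH]2)C=C1` gives 1380 nM; the two flank compound 2 on either side, both beyond the scatter. For the measured compounds named here, no pair of measured compounds differs in a single place, so the change leading to compound 4 `O=C1C=CC(O)(c2cc3ccccc3n2S(=O)(=O)c2ccc(F)cc2)C=C1` has to be read against the overall spread: 4-fluorophenyl in place of naphthalen-2-yl on a sulfonyl sulfur. Compound 3, which carries no sulfonyl group at all, gives the highest number, while compound 1 gives the lowest, so a sulfonyl bearing one six-membered aromatic ring of carbon only goes together with strong inhibition of growth in this series. The expected step, a 3.2-fold lower number from compound 2 to compound 4 (0.50 log units; beyond the scatter), is a moderate move toward a lower number, beyond the scatter, resting on compound 1 at 16 nM. Compound 4 is estimated at 60 nM, within a range from 15 nM to 250 nM.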

Compound 4, concentration for 50% growth inhibition: 230 nM
Estimate against measurement, compound 4: 3.8-fold (0.58 log units) below; low and high end bracket the measured number.
By their numbers in this assay, from the lowest: compound 1; then compounds 2 and 4 (each within the scatter of the next); then compound 3.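

In this assay the change to 4-fluorophenyl in place of naphthalen-2-yl on a sulfonyl sulfur gives a 1.2-fold higher number from compound 2 to compound 4 (0.08 log units; within the scatter), so this position accepts either aryl group without a readable difference between them. One six-membered aromatic ring of carbon only and two such rings therefore do not separate this pair, and a single ring on the sulfonyl does not by itself set the number. Nothing measured alongside these compounds speaks to a cause for this result.

Open, from the compounds shown here alone, is whether an aryl group is needed on the sulfonyl sulfur at all, which a methyl group or a longer alkyl chain there would test. Also open, going by these compounds, is whether an amine or a carboxylic acid on the phenyl ring is tolerated, and what the fluorine on the core of compound 1 contributes on its own.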